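A phenyl swap on a compound at the assay limit

A few compounds are considered here, and "the series" means these few. Any claim that something is new, unique, unknown or untested is made for them only; others in the source may bear on it.

Compound 1 `Cn1ccc2cc(-c3cc4nccc(-c5ccc(F)cc5)n4n3)ccc21`: 5210 nM
Compound 2 `COc1cc(-c2ccnc3cc(-c4cccc(C#N)c4)nn23)cc(OC)c1OC`: > 10000 nM (a limit)

In a functional assay on HeLa cells (Homo sapiens) for inhibition, read by CCK-8 assay, with a stated time of 48 h (a higher number here means a weaker inhibitor, a lower number a stronger inhibitor), compound 2 gives only a limit, > 10000 nM, so it has no exact value. Compound 3 `COc1cc(-c2ccnc3cc(-c4ccc(N(C)C)cc4)nn23)cc(OC)c1OC` has 4-(dimethylamino)phenyl in place of 3-cyanophenyl on an aromatic carbon of the five-membered aromatic ring (4-(dimethylamino)phenyl in place of 3-cyanophenyl on an aromatic carbon). Going by the values given here, no measured pair shows this swap, so the size of the change is uncertain. A modest gain in strength is expected, reaching about the level of compound 1 at 5210 nM. The expected change is an at least 2.5-fold lower number from compound 2 to compound 3 (0.39 log units; beyond the scatter). Compound 3 is estimated at 4000 nM, with an expected range of 600 nM to 15000 nM.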

Compound 3, half-maximal inhibitory concentration: 378 nM
For compound 3 the middle estimate is 11-fold (1.02 log units) above the measured one; measured number outside the range, below it.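

Replacing 3-cyanophenyl with 4-(dimethylamino)phenyl on this aromatic carbon of the five-membered ring gives, in this assay, an at least 26-fold lower number from compound 2 to compound 3 (1.42 log units; beyond the scatter). The group at this position can therefore strongly change the result on the same core. Compound 2 has only a limit, so the true step may be larger than the number printed: the limit of > 10000 nM in this assay, at which 1 of the 3 values shown sits.

On these data alone, the two groups differ in both their substituent and its place on the phenyl ring, so it remains open which of these matters. A 4-cyanophenyl or a 3-(dimethylamino)phenyl at this carbon would separate the two.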